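The compounds below may be only part of what the source reports. "The series", "measured", "known", "first", "only" and "open" are said of these compounds alone.

Measured so far:
compound 1 `C=CCCn1c(=O)c2[nH]cnc2n(CCC)c1=O`: 60 nM
compound 2 `CCCn1c(=O)n(CCCOC)c(=O)c2[nH]cnc21`: 12400 nM

In an assay on Cerebral cortex for binding affinity to adenosine receptor A1 (Cavia porcellus), read by radioligand binding (a lower number here means a stronger inhibitor, a higher number a weaker inhibitor), compound 1 gives 60 nM, the lower of the two numbers; compound 2 gives 12400 nM, a step of a 210-fold higher number from compound 1 to compound 2 (2.32 log units; beyond the scatter). The unmeasured compound 3 `CCCn1c(=O)n(CCCCC(C)=O)c(=O)c2[nH]cnc21` differs from compound 1 by 2-acetylethyl in place of vinyl on a saturated chain carbon, two bonds along the chain from an aromatic nitrogen. Going by the values given here, the one measured step that bears on this change is a 210-fold higher number from compound 1 to compound 2 (2.32 log units; beyond the scatter), where an oxygen-bearing chain also replaced the vinyl group at the same place. That step was large and beyond the scatter, so a change of the same kind, a weakening, is expected for compound 3. The entering group here is 2-acetylethyl rather than methoxymethyl, and the size of the expected step is less certain. Compound 3 is therefore estimated to give 3000 nM in this assay, within a range of 500 nM to 15000 nM, an expected step of a 50-fold higher number from compound 1 to compound 3 (1.70 log units; beyond the scatter).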

Compound 3, inhibition constant: 23100 nM
Estimate against measurement, compound 3: 7.7-fold (0.89 log units) below; measured number above the stated range.
By their numbers in this assay, from the lowest: compound 1; then compounds 2 and 3 (each within the scatter of the next).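

In this assay the step is a 390-fold higher number from compound 1 to compound 3 (2.59 log units; beyond the scatter) when 2-acetylethyl enters in place of vinyl on a saturated chain carbon, so the large loss seen with methoxymethyl is not confined to that one group. The step of a 1.9-fold higher number from compound 2 to compound 3 (0.27 log units; within the scatter) lies within the scatter, so 2-oxopropyl in place of methoxy leaves no difference that can be read, and the two chains stand level in this assay. Nothing in the data explains why either chain lies so far from compound 1.

The compounds shown do not separate the oxygen in these chains from their length, so a plain longer carbon chain such as pentyl at this place remains an open case. As far as these compounds go, whether an amine or a carboxylic acid at the end of the chain would fare alike is also open.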